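Working notes: the step from compound 3 to compound 4

The source may report more compounds than this note shows. Statements on the series, on what has been measured and on what is new or still open speak of the compounds shown alone.

Measured compounds:
Compound 1 `CCCn1c(=O)[nH]c2nc(-c3ccc(S(=O)(=O)N4CCN(Cc5ccc(Br)cc5)CC4)cc3)[nH]c2c1=O`. In an assay on CHO cells for displacement of a labelled ligand from adenosine receptor A1 (Homo sapiens), read by scintillation counting, with a stated time of 90 min, in the presence of a further agent that is not named here (a lower number here means a stronger inhibitor, a higher number a weaker inhibitor), compound 1 gives > 1000 nM, which is a limit of the assay and not a number.
Compound 2 `CCCn1c(=O)[nH]c2nc(-c3ccc(S(=O)(=O)N4CCN(c5ccccc5Cl)CC4)cc3)[nH]c2c1=O`. In this assay compound 2 gives > 1000 nM, again a limit.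
Compound 3 `CCCn1c(=O)[nH]c2nc(-c3ccc(S(=O)(=O)N4CCN(c5ccc(I)cc5)CC4)cc3)[nH]c2c1=O`. In this assay compound 3 gives > 1000 nM, also a limit.

Compound 3 therefore stands at the limit shared by every value in the series, as described by the limit of > 1000 nM in this assay, at which 3 of the 3 values shown sit. The unmeasured compound 4 `CCCn1c(=O)[nH]c2nc(-c3ccc(S(=O)(=O)N4CCN(c5ccccc5C)CC4)cc3)[nH]c2c1=O` differs from compound 3 only at the ring nitrogen: 2-methylphenyl in place of 4-iodophenyl on an amine nitrogen in a ring.

For the measured compounds named here, three steps bear on the change, all between compounds that share this limit: a step that the two limits leave unreadable from compound 1 to compound 3, a step that the two limits leave unreadable from compound 2 to compound 3 and a step that the two limits leave unreadable from compound 1 to compound 2. None of them gives a readable size, so no direction can be taken from them. What the three values do show is that a 4-bromobenzyl, a 2-chlorophenyl and a 4-iodophenyl on this nitrogen all leave the measurement at the limit. The expected step that the limit leaves unreadable from compound 3 to compound 4 is therefore no step beyond the scatter, with a limit the most likely outcome. For compound 4 the estimate in this assay is 2500 nM, with a range from 700 nM to 15000 nM.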

Compound 4, inhibition constant: 419 nM
For compound 4 the middle estimate is 6.0-fold (0.78 log units) above the measured one; measured number outside the range, below it.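

In this assay, 2-methylphenyl in place of 4-iodophenyl on the amine nitrogen in a ring gives an at least 2.3-fold lower number from compound 3 to compound 4 (0.37 log units; beyond the scatter), which shows that a change at this position can bring the measurement off the limit. The narrowest comparison is methyl in place of chloro on an aromatic carbon, with an at least 2.3-fold lower number from compound 2 to compound 4 (0.37 log units; beyond the scatter), so the group on the same phenyl matters here, and the change from 4-bromobenzyl gives an at least 2.3-fold lower number from compound 1 to compound 4 (0.37 log units; beyond the scatter). Compound 1, compound 2 and compound 3 each stay at a limit of the assay and not a number, and the steps among them cannot be read, so compound 4 is the only one of the four that gives a number: the limit of > 1000 nM in this assay, at which 3 of the 4 values shown sit.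

From the compounds shown here alone, all three new steps are lower bounds, so their true sizes remain open, as does any order among compound 1, compound 2 and compound 3. Also open, going by these compounds, is whether the gain belongs to methyl as such or to its place on the phenyl, which a 4-methylphenyl, a 2-methoxyphenyl, a 2-ethylphenyl or an unsubstituted phenyl on this nitrogen would help to settle.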